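The compounds below may be only part of what the source reports. "The series", "measured", "known", "first", "only" and "open" are said of these compounds alone.

Compound 1 `COc1ccc(Nc2n[n+]([O-])c3ccccc3[n+]2[O-])cc1`: 10100 nM
Compound 2 `C=CCNc1n[n+]([O-])c2ccccc2[n+]1[O-]`: > 56000 nM (a limit of the assay, not a number)

Both results come from a functional assay on HepG2 cells (Homo sapiens) for cytotoxicity, read by MTT assay, with a stated time of 48 h; a lower number here means a stronger inhibitor, a higher number a weaker inhibitor. Compound 2 stands at > 56000 nM, which is a limit and not a number. Only compound 1 gives a true number, at 10100 nM, so the measured data offer a single firm point of reference.

The next compound, compound 3 `[O-][n+]1nc(Nc2ccccc2)[n+]([O-])c2ccccc21`, keeps the shared core of compound 2 but has phenyl in place of allyl on a nitrogen on an aromatic ring. For the measured compounds named here, no pair of measured compounds shows what a change like this does, so what follows is a judgement and not a reading from data. Compound 1 at 10100 nM shows that a real number can be reached in this assay, and this guides the expectation. The expected step of an at least 3.7-fold lower number from compound 2 to compound 3 (0.57 log units; beyond the scatter) is a clear one beyond the usual scatter, towards a lower number and so a stronger inhibitor. A second result that is only a limit cannot be ruled out. For compound 3 the estimated value is 15000 nM, with an expected range of 5000 nM to 50000 nM.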

Compound 3, half-maximal inhibitory concentration: 15000 nM
Estimate against measurement, compound 3: no gap at the digits printed; low and high end bracket the measured number.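

In this assay, for the compounds shown here, phenyl in place of allyl on a nitrogen on an aromatic ring gives an at least 3.7-fold lower number from compound 2 to compound 3 (0.57 log units; beyond the scatter), which is the first evidence that the group on this nitrogen can change the result. Hydrogen in place of methoxy on an aromatic carbon gives a 1.5-fold higher number from compound 1 to compound 3 (0.17 log units; within the scatter), so the two compounds that carry an aromatic ring on this nitrogen cannot be told apart, and the methoxy group makes no readable difference here. The result for compound 2 is a limit of the assay, not a number: the limit of > 56000 nM in this assay, at which 1 of the 3 values shown sits.

The compounds shown do not settle whether the aromatic ring itself matters at this nitrogen, and a saturated chain such as propyl or a benzyl group would be needed to separate the ring from other differences between phenyl and allyl. On the phenyl ring, only methoxy and hydrogen can be compared so far, which leaves open whether a chlorine, an amine or a carboxylic acid on that ring would shift the result beyond the usual scatter.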